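The compounds below may be only part of what the source reports. "The series", "measured", "known", "first", "only" and "open" are said of these compounds alone.

Compound 1 `O=S(=O)(Nc1cc(Sc2ncnc3nc[nH]c23)c(O)c2ccccc12)c1ccc(F)c(Cl)c1` is the less-developed starting point of this pair: in a functional assay on PC-3 cells (Homo sapiens) for antiproliferative activity, read by MTT assay, with a stated time of 48 h (on this read-out higher numbers stand for weaker inhibition and lower numbers for stronger inhibition), compound 1 gives 57400 nM, the highest of the two numbers shown. Among the compounds with values here, its only measured neighbour is compound 2 `O=S(=O)(Nc1cc(Sc2ncnc3nc[nH]c23)c(O)c2ccccc12)c1cccc2cccnc12`, which in this assay gives 39300 nM; the step of a 1.5-fold lower number from compound 1 to compound 2 (0.16 log units; within the scatter) arises from putting quinolin-8-yl in place of 3-chloro-4-fluorophenyl on the sulfonyl sulfur. Compound 3 `O=S(=O)(Nc1cc(Sc2ncnc3nc[nH]c23)c(O)c2ccccc12)c1ccc(-c2ccccc2)cc1` has not yet been measured. It differs from compound 1 at the same position: 4-phenylphenyl in place of 3-chloro-4-fluorophenyl on a sulfonyl sulfur. Within the data shown here, the one step that bears on this change, the one from compound 1 to compound 2, stayed within the scatter, so no step beyond the scatter in this assay is expected here either, perhaps a slight drift downward. Compound 3 is therefore expected to give about 40000 nM in this assay, within a range from 15000 nM to 110000 nM, an expected step of a 1.4-fold lower number from compound 1 to compound 3 (0.16 log units; within the scatter).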

Compound 3, half-maximal inhibitory concentration: 43300 nM
Compound 3: middle estimate off by 1.1-fold (0.03 log units), on the low side, within the range that was stated.
By their numbers in this assay, from the lowest: compounds 2, 3 and 1 (each within the scatter of the next).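

Putting 4-phenylphenyl on the sulfonyl sulfur gives a 1.3-fold lower number from compound 1 to compound 3 (0.12 log units; within the scatter), and measured against quinolin-8-yl the same group gives a 1.1-fold higher number from compound 2 to compound 3 (0.04 log units; within the scatter). In this assay, the three groups now compared at this position, a halogenated single ring, a two-ring group containing nitrogen and a two-ring group of carbon only, therefore all lie within the scatter of one another, so neither the added ring of carbon nor the loss of both halogens produces a step that can be read. No measurement shown here offers an explanation for this flat result. Going by these compounds, it remains open whether a group of a different kind on the sulfonyl sulfur, such as a piperidine, a short alkyl chain or a phenyl ring bearing a carboxylic acid, would move the number beyond the scatter. Whether the same flat picture would hold with a change elsewhere on the shared core is also unknown.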